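Permeability of an aryl urea: nitro to amino

A few compounds are considered here, and "the series" means these few. Any claim that something is new, unique, unknown or untested is made for them only; others in the source may bear on it.

Of the compounds shown here, three sharing one core have been measured in an ADME assay for permeability, using PAMPA, at pH 7.4; a higher number here means that the compound crosses the layer faster, a lower number that the compound crosses the layer more slowly. Compound 1 `Cc1cc(NC(=O)Nc2ncccc2C)c2ccccc2n1` gives 369 10^-6 cm/s, compound 2 `CSc1ccccc1NC(=O)Nc1cc(C)nc2ccccc12` gives 1260 10^-6 cm/s, and compound 3 `Cc1cc(NC(=O)Nc2ccccc2[N+](=O)[O-])c2ccccc2n1` gives 204 10^-6 cm/s. Within the data shown here, compound 3 therefore holds the lowest of the three numbers, although its gap to compound 1 lies within the scatter; only the step of a 6.2-fold lower number from compound 2 to compound 3 (0.79 log units; beyond the scatter) is beyond it. Compound 4 `Cc1cc(NC(=O)Nc2ccccc2N)c2ccccc2n1` differs from compound 3 by amino in place of nitro on an aromatic carbon. Among the measured compounds shown here, no measured step swaps these two groups, so the single relevant step is the drop from compound 2 to compound 3, which does not show what a change on the same carbon to amino would bring. A small step, at most near the scatter, is expected in this assay: a 1.4-fold lower number from compound 3 to compound 4 (0.13 log units; within the scatter). Compound 4 is thus estimated at 150 10^-6 cm/s, within 60 10^-6 cm/s to 380 10^-6 cm/s.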

Compound 4, apparent permeability: 300 10^-6 cm/s
Compound 4: middle estimate off by 2.0-fold (0.30 log units), on the low side; low and high end bracket the measured number.
By their numbers in this assay, from the lowest: compounds 3, 4 and 1 (each within the scatter of the next); then compound 2.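

In this assay the direct swap on this aromatic carbon gives a 1.5-fold higher number from compound 3 to compound 4 (0.17 log units; within the scatter) and so leaves nitro and amino indistinguishable. Methylsulfanyl still stands apart, with a 4.2-fold lower number from compound 2 to compound 4 (0.62 log units; beyond the scatter) on the same carbon, while a 1.2-fold lower number from compound 1 to compound 4 (0.09 log units; within the scatter) leaves 2-aminophenyl and 3-methylpyridin-2-yl on the amide-type nitrogen indistinguishable too. Nothing available explains these numbers. On these data alone, whether a carboxylic acid, a methoxy group or a longer chain on this carbon would fall with amino and nitro or with methylsulfanyl stays open.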